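Cytotoxicity notes on the shared-core series

The source may report more compounds than this note shows. Statements on the series, on what has been measured and on what is new or still open speak of the compounds shown alone.

Compound 1, `O=C(c1ccc2c(c1)OCCO2)C1CCN(Cc2coc(-c3ccc(F)cc3)n2)CC1`, gives > 150 ug/mL in an ADME assay on HEK293 cells (Homo sapiens) for cytotoxicity, read by MTT assay, with a stated time of 36 h; a lower number here means a stronger inhibitor, a higher number a weaker inhibitor; this is a limit of the assay, not a number.
Compound 2, `O=C(c1ccc2c(c1)CCCC2)C1CCN(Cc2coc(-c3ccc(F)cc3)n2)CC1`, gives > 150 ug/mL in this assay; this too is a limit.
Compound 3, `O=C(c1ccc(F)c(F)c1)C1CCN(Cc2coc(-c3ccc(F)cc3)n2)CC1`, gives > 150 ug/mL in this assay; this is again a limit.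

Compound 3 therefore stands only as a limit in this assay, and the two further values shown are limits as well, all of them sitting at the limit of > 150 ug/mL in this assay, at which 3 of the 3 values shown sit. The steps between the measured compounds, a step that the two limits leave unreadable from compound 1 to compound 2, a step that the two limits leave unreadable from compound 1 to compound 3 and a step that the two limits leave unreadable from compound 2 to compound 3, cannot be read from two limits and give no size in either direction. Compound 4, `O=C(c1ccccc1)C1CCN(Cc2coc(-c3ccc(F)cc3)n2)CC1`, is the next compound in the series, and the change from compound 3 is phenyl in place of 3,4-difluorophenyl on a carbonyl carbon. Three exchanges of the group on the carbonyl carbon have each left the value at the limit of > 150 ug/mL in this assay, at which 3 of the 3 values shown sit, so no step beyond the scatter is expected in this assay from compound 3 to compound 4, and the likeliest outcome is that compound 4 also returns only a limit. The expected step is a step that the limit leaves unreadable from compound 3 to compound 4. Compound 4 is thus estimated at 200 ug/mL, with a range from 100 ug/mL to 400 ug/mL.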

Compound 4, half-maximal inhibitory concentration: > 150 ug/mL
Compound 4: no number, only a limit; the forecaster's own chance of this, stated with the estimate: 85%; the middle value does not contradict the limit.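

Compound 4 gives > 150 ug/mL in this assay, which is again a limit and not a number. The steps to compound 4 from compound 1, compound 2 and compound 3 therefore cannot be read, and the series stands at one value: the limit of > 150 ug/mL in this assay, at which 4 of the 4 values shown sit.

The compounds shown leave open how far each lies beyond this limit, and whether any group on the carbonyl carbon gives a readable number in this assay.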